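The source may hold more compounds than are shown below. What is called first, only, known or untested is meant among the compounds shown, and "the series" means these compounds.

Measured compounds:
- Compound 1, `O=[N+]([O-])c1ccc(Sc2cn(-c3ccc4c(c3)B(O)OC4)c3ccccc23)cc1`: in an ADME assay on L929 cells (Mus musculus) for cytotoxicity, read by resazurin assay, with a stated time of 72 h (on this read-out lower numbers stand for stronger inhibition and higher numbers for weaker inhibition), compound 1 gives > 10 ug/mL, which is a limit of the assay and not a number.
- Compound 2, `OB1OCc2ccc(-n3cccc3)cc21`: in this assay compound 2 gives > 10 ug/mL, again a limit of the assay.
- Compound 3, `CCCNC(=O)c1cccn1-c1ccc2c(c1)B(O)OC2`: in this assay compound 3 gives > 10 ug/mL, also a limit of the assay.

Compound 3 therefore stands where every measured compound of the series stands: at the limit, with no number to place it against the other two. Among the compounds with values here, the one single-point change measured so far, a step that the two limits leave unreadable from compound 2 to compound 3, cannot be read in size, because both ends sit at the limit of > 10 ug/mL in this assay, at which 3 of the 3 values shown sit.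

Compound 4, `COc1ccc(CNC(=O)c2cccn2-c2ccc3c(c2)B(O)OC3)cc1`, differs from compound 3 by 4-methoxyphenyl in place of ethyl on a saturated chain carbon bound to an amide-type nitrogen. Within the data shown here, no measured step in this assay speaks to a change of this kind, and the only pattern seen is that all three measured compounds reach the limit. On that basis no step beyond the scatter is expected, and a step that the limit leaves unreadable from compound 3 to compound 4 is estimated to be small in this assay. Compound 4 is expected to sit at about 15 ug/mL, with a range from 6 ug/mL to 40 ug/mL, most likely reported again only as a limit.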

Compound 4, half-maximal inhibitory concentration: > 10 ug/mL
Compound 4 gave a limit, no number; the forecaster's own chance of this, stated with the estimate: 80%; the middle value does not contradict the limit.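

In this assay compound 3 and compound 4 both give only a limit of the assay, so no new step can be read for the change from propyl to 4-methoxybenzyl, and the series stays at one place: the limit of > 10 ug/mL in this assay, at which 4 of the 4 values shown sit.

The compounds shown leave open how large any of these changes is, and which change, if any, would bring a compound of the series off the limit in this assay.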